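Cytotoxicity Limits Across Three Measured Compounds

This account rests on a few compounds, and the source may have more. Where it says the series, first, only, none or still open, it means among the compounds named here.

Compound 1, `O=C(Nc1cc2nc(C3CCCCC3)[nH]c2cc1N1CCCC1)OCC(F)(F)F`, gives > 100 ug/mL in an ADME assay on Vero cells (Chlorocebus sabaeus) for cytotoxicity, read by resazurin assay, with a stated time of 3 days; on this read-out higher numbers stand for weaker inhibition and lower numbers for stronger inhibition.
Compound 2, `CCCCOC(=O)Nc1cc2nc(C3CCCCC3)[nH]c2cc1N(C)CCN(C)C`, gives > 100 ug/mL in this assay.
Compound 3, `CN(C)c1cc2[nH]c(C3CCCCC3)nc2cc1NC(=O)c1ccc(F)cc1`, gives > 100 ug/mL in this assay.

Each of these three values is a limit of this assay rather than a number. Compound 2 thus stands at the limit of > 100 ug/mL in this assay, at which 3 of the 3 values shown sit, and the same holds for compound 1 and compound 3, so no ranking among the three can be drawn from what is shown.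

The step of interest leads from compound 2 to compound 4, `CCCCOC(=O)Nc1cc2nc(C3CCCCC3)[nH]c2cc1N(CC)CCN(CC)CC`, which has not yet been measured in this assay. The structural change is (2-(diethylamino)ethyl)(ethyl)amino in place of (2-(dimethylamino)ethyl)(methyl)amino on an aromatic carbon.

Among the measured compounds shown here, no measured step between compounds differing in one place is available, so the expectation rests on the values alone. Because compound 2 sits at > 100 ug/mL, and because compound 1 and compound 3 also sit at the limit of > 100 ug/mL in this assay, at which 3 of the 3 values shown sit, compound 4 is expected to remain at or around that limit, with a step from compound 2 to compound 4 of a number no higher from compound 2 to compound 4 (the limit leaves the size open), which is no change beyond the scatter. Compound 4 is estimated at 100 ug/mL in this assay, within 50 ug/mL to 200 ug/mL.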

Compound 4, half-maximal inhibitory concentration: > 50 ug/mL
Compound 4 ended at the assay's limit (the forecaster's own chance of this, stated with the estimate: 80%); the middle value is on the limit's open side.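

Compound 2 and compound 4 are both recorded only as limits in this assay, and the step between them cannot be read. The compounds shown leave open where any of them would give an actual number in this assay, and whether (2-(diethylamino)ethyl)(ethyl)amino and (2-(dimethylamino)ethyl)(methyl)amino differ there at all.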